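A few compounds are considered here, and "the series" means these few. Any claim that something is new, unique, unknown or untested is made for them only; others in the source may bear on it.

Measured compounds:
compound 1 `COc1ccc(OC)c(/C=C/S(=O)(=O)Cc2ccc(OC)c(N)c2)c1`: 750 nM
compound 2 `COc1ccc(CS(=O)(=O)/C=C/c2c(OC)cccc2OC)c(N)c1`: 750 nM
compound 3 `COc1ccc(CS(=O)(=O)/C=C/c2c(OC)cc(OC)cc2OC)c(N)c1`: 25 nM

In a functional assay on K562 cells (Homo sapiens) for cytotoxicity, read by trypan blue exclusion, with a stated time of 96 h (a higher number here means a weaker inhibitor, a lower number a stronger inhibitor), compound 1 and compound 2 give the same figure at the digits recorded, and the two lie within the scatter of each other, so no order between them is claimed. Compound 1 and compound 2 contain the same atoms joined differently; the difference between the two cores is not broken down here.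

From compound 2 to compound 3 the change is methoxy in place of hydrogen on an aromatic carbon. The step in this assay is a 30-fold lower number from compound 2 to compound 3 (1.48 log units; beyond the scatter).

Compound 4 `COc1ccc(CS(=O)(=O)/C=C/c2cc(OC)c(OC)cc2OC)cc1N` has not yet been measured in this assay. It differs from compound 1 by methoxy in place of hydrogen on an aromatic carbon. For the measured compounds named here, this is the same kind of change as the one from compound 2 to compound 3, not the same change: in compound 3 the entering methoxy sits meta to two methoxy groups and para to a large group, whereas in compound 4 it sits ortho to a methoxy group, meta to a methoxy group and para to a large group.

Going by the values given here, the expectation for compound 4 rests on the single measured instance of this kind of change, the step of a 30-fold lower number from compound 2 to compound 3 (1.48 log units; beyond the scatter), and is tempered because a 30-fold lower number from compound 2 to compound 3 (1.48 log units; beyond the scatter) was measured with the entering methoxy meta to two methoxy groups and para to a large group, whereas in compound 4 the entering methoxy sits ortho to a methoxy group. For compound 4 the step from compound 1 is estimated at a 9.4-fold lower number from compound 1 to compound 4 (0.97 log units; beyond the scatter), smaller than the measured one. The estimate for compound 4 in this assay is 80 nM, with a range from 20 nM to 300 nM.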

Compound 4, half-maximal inhibitory concentration: 250 nM
Estimate against measurement, compound 4: 3.1-fold (0.49 log units) below, and the stated range covers the measured number.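

In this assay, methoxy in place of hydrogen on an aromatic carbon again lowers the number on the core of compound 1, giving a 3.0-fold lower number from compound 1 to compound 4 (0.48 log units; beyond the scatter), but the size of the step does not carry over from the earlier pair: the same change on two cores in this assay, a 30-fold lower number (1.48 log units; beyond the scatter) from compound 2 to compound 3 and a 3.0-fold lower number (0.48 log units; beyond the scatter) from compound 1 to compound 4, 10-fold (1.00 log units) apart, beyond the scatter of two such steps

The direction is thus shared by these two pairs, which is too few to support a rule for any further core, and the size of the step cannot be assumed when the change is moved to another core in this series. What the pairs do not show is whether the gap belongs to the core or to the place of the entering methoxy, which in compound 4 sits ortho to a methoxy group, meta to a methoxy group and para to a large group; the two pairs differ in both, and nothing shown separates the two.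

For the compounds shown here, still open is what the core of compound 1 would give with the entering methoxy placed as in compound 3, the one comparison that would separate core from place. Also open, as far as these compounds go, is whether a group other than methoxy on the same aromatic carbon, such as ethoxy, a hydroxyl or a carboxylic acid, would follow either step.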